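Fluoro to ethynyl: working notes on clearance

The source may hold more compounds than are shown below. What is called first, only, known or untested is meant among the compounds shown, and "the series" means these compounds.

Measured in an ADME assay on microsomes from liver (Canis lupus familiaris) for metabolic stability, read by LC-MS, using NADPH, with a stated time of 10 min, tested at 0.1 uM; on this read-out lower numbers stand for slow clearance and higher numbers for fast clearance:
compound 1 `CC1SC(c2cccc(C(=O)NCCCCc3ccccc3)c2)N(c2ccc(C3CC3)cc2)C1=O`: 1750 mL.min-1.g-1
compound 2 `COc1ccccc1N1C(=O)CSC1c1cc(F)cc(C(=O)NCCCCc2ccccc2)c1`: 2170 mL.min-1.g-1

Compound 2 stands level with compound 1, as their two values lie within the usual scatter of each other. The two compounds differ in more than one place, so the pair gives no guide to any single group.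

Compound 3 `C#Cc1cc(C(=O)NCCCCc2ccccc2)cc(C2SCC(=O)N2c2ccccc2OC)c1` is not yet measured. It carries ethynyl in place of fluoro on an aromatic carbon, meta to two large groups: ethynyl in place of fluoro on an aromatic carbon. Among the measured compounds shown here, no measured step covers this exchange, so no change beyond the scatter is expected in this assay, and the direction stays open. The expectation is anchored on compound 2 at 2170 mL.min-1.g-1. The estimated step is a 1.1-fold higher number from compound 2 to compound 3 (0.03 log units; within the scatter). For compound 3 the expected value is 2300 mL.min-1.g-1, within an estimated range of 1200 mL.min-1.g-1 to 4300 mL.min-1.g-1.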

Compound 3, intrinsic clearance in microsomes: 1750 mL.min-1.g-1
Compound 3: the middle estimate sits 1.3-fold (0.12 log units) above what was measured, within the range that was stated.
By their numbers in this assay, from the lowest: compounds 1, 3 and 2 (each within the scatter of the next).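

In this assay, among the compounds shown here, the exchange of fluoro for ethynyl on an aromatic carbon, meta to two large groups, gives a 1.2-fold lower number from compound 2 to compound 3 (0.09 log units; within the scatter) and provides the first comparison that differs in one place. At this position, the larger ethynyl group is therefore tolerated with no change beyond the scatter, which compounds 1 and 2 alone could not show. No measured property bears on this result, so it remains an observation without an assigned cause.

From the compounds shown here alone, whether an amine, a carboxylic acid or a nitrile at this position would move clearance beyond the scatter remains open. Also open, going by these compounds, is whether the same exchange of fluoro for ethynyl would read alike on a core carrying other groups, such as the core of compound 1.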